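The compounds below may be only part of what the source reports. "The series", "measured", "known", "first", "only" and "open" are said of these compounds alone.

Measured in an assay on CHO-K1 cells for displacement of a labelled ligand from melanin-concentrating hormone receptor 1 (Homo sapiens), read by scintillation proximity assay, with a stated time of 2 h; on this read-out lower numbers stand for stronger inhibition and higher numbers for weaker inhibition:
- compound 1 `Cc1nc(N2CCC(NS(=O)(=O)N(C)C)CC2)nc2ccc(NC(=O)/C=C/c3ccc(OC(F)(F)F)cc3)cc12`: 105 nM
- compound 2 `COCC(=O)NC1CCN(c2nc(C)c3cc(NC(=O)/C=C/c4ccc(OC(F)(F)F)cc4)ccc3n2)CC1`: 32 nM
- compound 3 `Cc1nc(N2CCC(N3CCNC3=O)CC2)nc2ccc(NC(=O)/C=C/c3ccc(OC(F)(F)F)cc3)cc12`: 66 nM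

Compound 3 stands second highest of the three numbers. Its nearest neighbour is compound 1, and the step of a 1.6-fold lower number from compound 1 to compound 3 (0.20 log units; within the scatter) lies within the scatter; its furthest is compound 2, and the step of a 2.1-fold higher number from compound 2 to compound 3 (0.31 log units; beyond the scatter) is a modest one beyond the scatter.

Compound 4 `Cc1nc(N2CCC(N3CCCS3(=O)=O)CC2)nc2ccc(NC(=O)/C=C/c3ccc(OC(F)(F)F)cc3)cc12` is the next step from compound 3. The change is a group of 7 heavy atoms (3 carbon, 1 nitrogen, 2 oxygen, 1 sulfur; one five-membered non-aromatic ring with 2 hetero atoms) in place of a group of 6 heavy atoms (3 carbon, 2 nitrogen, 1 oxygen; one five-membered non-aromatic ring with 2 hetero atoms), on a saturated ring carbon. All three measured steps in this assay concern the same saturated ring carbon: a 3.3-fold lower number from compound 1 to compound 2 (0.52 log units; beyond the scatter) and a 2.1-fold higher number from compound 2 to compound 3 (0.31 log units; beyond the scatter) were modest, and a 1.6-fold lower number from compound 1 to compound 3 (0.20 log units; within the scatter) stayed within the scatter. Exchanges of the group at this carbon have therefore moved the number by modest amounts at most, and none of the measured compounds carries the entering group, so nothing points to a larger shift in this assay. The step of a 1.1-fold higher number from compound 3 to compound 4 (0.03 log units; within the scatter) is expected to stay within the scatter. Compound 4 is accordingly estimated at 70 nM, with a range from 28 nM to 175 nM.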

Compound 4, half-maximal inhibitory concentration: 4 nM
Compound 4: the middle estimate sits 18-fold (1.24 log units) above what was measured; the measured number lies below the stated range.
By their numbers in this assay, from the lowest: compound 4; then compound 2; then compounds 3 and 1 (each within the scatter of the next).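

In this assay, this saturated ring carbon proves able to carry a large shift, not only the modest ones seen before: a 17-fold lower number from compound 3 to compound 4 (1.22 log units; beyond the scatter). A five-membered non-aromatic ring with 2 hetero atoms is not enough for this shift, since it is present on both sides of that step, and compound 4 also stands apart from the open-chain groups, with an 8.0-fold lower number from compound 2 to compound 4 (0.90 log units; beyond the scatter) and a 26-fold lower number from compound 1 to compound 4 (1.42 log units; beyond the scatter). Nothing available bears on what lies behind the lower number of compound 4.

The step to compound 4 changes the ring atoms and removes the hydrogen-bond donor together, so the compounds shown cannot separate these two changes. On these data alone, how the number responds to a six-membered sulfur-bearing ring, a simple amine or a carboxylic acid at this carbon remains open.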